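This account rests on a few compounds, and the source may have more. Where it says the series, first, only, none or still open, it means among the compounds named here.

Compounds measured in an assay on isolated protein for inhibition of Beta-glucosidase (Homo sapiens) (on this read-out lower numbers stand for stronger inhibition and higher numbers for weaker inhibition), so far:
Compound 1, `Cc1cccc(-c2ccc(COCCCCCN3C[C@H](O)[C@@H](O)[C@H](O)[C@H]3CO)cc2)c1`, gives 2 nM.
Compound 2, `N#Cc1ccc(-c2ccc(COCCCCCN3C[C@H](O)[C@@H](O)[C@H](O)[C@H]3CO)cc2)cc1`, gives 3 nM.
Compound 3, `OC[C@@H]1[C@@H](O)[C@H](O)[C@@H](O)CN1CCCCCOCc1ccc(-c2cc(C(F)(F)F)cc(C(F)(F)F)c2)cc1`, gives 15 nM.

All three share the same core and differ only in the aromatic group at the far end of the molecule. Compound 2 stands second highest of the three numbers in this assay: compound 1 sits nearest to it, and the gap between the two is a 1.5-fold higher number from compound 1 to compound 2 (0.18 log units; within the scatter), so these two are indistinguishable; compound 3 gives the highest number, and its value stands clearly apart from that of compound 2.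

The new compound 4, `OC[C@@H]1[C@@H](O)[C@H](O)[C@@H](O)CN1CCCCCOCc1ccc(-c2ccnc(F)c2)cc1`, changes compound 2 in one place: 2-fluoropyridin-4-yl in place of 4-cyanophenyl on an aromatic carbon. For the measured compounds named here, the only directly comparable step, the swap of 3-methylphenyl for 4-cyanophenyl, produced no change beyond the scatter in this assay, which suggests that this end of the molecule tolerates moderate variation, although the higher number of compound 3 shows that a larger aromatic group is not without effect. For compound 4 the expected step is therefore small, a 1.7-fold higher number from compound 2 to compound 4 (0.22 log units; within the scatter), with no clear direction. The estimate for compound 4 in this assay is 5 nM, within a range from 1.5 nM to 15 nM.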

Compound 4, half-maximal inhibitory concentration: 4 nM
Compound 4: middle estimate off by 1.3-fold (0.10 log units), on the high side, and the stated range covers the measured number.
By their numbers in this assay, from the lowest: compounds 1, 2 and 4 (each within the scatter of the next); then compound 3.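

In this assay, replacing the 4-cyanophenyl group with 2-fluoropyridin-4-yl gives a 1.3-fold higher number from compound 2 to compound 4 (0.12 log units; within the scatter), and replacing the 3-methylphenyl group with it gives a 2.0-fold higher number from compound 1 to compound 4 (0.30 log units; within the scatter), so compound 1, compound 2 and compound 4 cannot be told apart. The earlier step compared only rings of carbon, whereas this result shows that a six-membered aromatic ring with a hetero atom can stand at this position, and that neither the nitrile nor the methyl group is required to keep the number within the scatter. Nothing available explains why these groups read alike.

On these data alone, it remains open whether an amine or a carboxylic acid on this outer ring would keep the number in the same range. A saturated cyclohexyl ring in place of the aromatic one is also an open case.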